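Amide-nitrogen aryl variation across one shared core

This account rests on a few compounds, and the source may have more. Where it says the series, first, only, none or still open, it means among the compounds named here.

Measured compounds and values in a functional assay on NCI-H1975 cells (Homo sapiens) for inhibition, read by MTT assay, with a stated time of 72 h; on this read-out lower numbers stand for stronger inhibition and higher numbers for weaker inhibition:
compound 1 `O=C(CSc1nc(Nc2ccccc2)c2ccccc2n1)Nc1cccc(Br)c1` gives 10100 nM
compound 2 `O=C(CSc1nc(Nc2ccccc2)c2ccccc2n1)Nc1cccc([N+](=O)[O-])c1` gives 17900 nM
compound 3 `O=C(CSc1nc(Nc2ccccc2)c2ccccc2n1)Nc1ccc(C(F)(F)F)cc1` gives 11700 nM

All three compounds share one core and differ only in the aryl group on the amide-type nitrogen. Compound 3 sits second highest of the three numbers; its nearest neighbour is compound 1, with a 1.2-fold higher number from compound 1 to compound 3 (0.06 log units; within the scatter), and its furthest is compound 2, with a 1.5-fold lower number from compound 2 to compound 3 (0.18 log units; within the scatter). Between compound 1 and compound 2 the step is a 1.8-fold higher number from compound 1 to compound 2 (0.25 log units; within the scatter). Every step among the measured compounds therefore lies within the scatter, and no ordering among them can be stated.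

Compound 4 `O=C(CSc1nc(Nc2ccccc2)c2ccccc2n1)Nc1ccc(Cl)c(Cl)c1` has not yet been measured in this assay. It differs from compound 3 by 3,4-dichlorophenyl in place of 4-(trifluoromethyl)phenyl on an amide-type nitrogen. The three measured steps all bear on this change, since each also swaps one aryl group for another at the same amide-type nitrogen, and none of them moved the number beyond the scatter. The step from compound 3 to compound 4 is therefore expected to be small as well, with no direction beyond the scatter, giving a 1.0-fold higher number from compound 3 to compound 4 (0.01 log units; within the scatter). For compound 4 the estimated value in this assay is 12000 nM, with an expected range from 6000 nM to 25000 nM.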

Compound 4, half-maximal inhibitory concentration: 10400 nM
Compound 4: middle estimate off by 1.2-fold (0.06 log units), on the high side; low and high end bracket the measured number.
By their numbers in this assay, from the lowest: compounds 1, 4, 3 and 2 (each within the scatter of the next).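

In this assay, going by these compounds alone, 3,4-dichlorophenyl on the amide-type nitrogen is the first aryl group here to carry two ring substituents, yet the steps to compound 4 from the earlier compounds all stay within the scatter (a 1.1-fold lower number from compound 3 to compound 4 (0.05 log units; within the scatter)), (a 1.7-fold lower number from compound 2 to compound 4 (0.24 log units; within the scatter)) and (a 1.0-fold higher number from compound 1 to compound 4 (0.01 log units; within the scatter)). The position has now taken bromo, nitro, trifluoromethyl and a pair of chloro substituents without any step beyond the scatter, so adding a second substituent to the ring gives no readable change, and the four compounds still cannot be ordered. No supporting data bear on this result, and nothing can be said about what lies behind it.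

On these data alone, all four groups on this nitrogen are substituted phenyl rings with halogen, trifluoromethyl or nitro substituents, so it remains open whether a phenyl ring bearing a carboxylic acid or a dimethylamino group, or a cyclohexyl group or longer alkyl chain in place of the ring, would move the number beyond the scatter. The rest of the shared core is the same in all four compounds, which leaves open how changes outside this position would read.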